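Aryl swap on the sulfonamide nitrogen, compound 3 to compound 4

The source may hold more compounds than are shown below. What is called first, only, known or untested is meant among the compounds shown, and "the series" means these compounds.

In a functional assay on cells (leukaemia cell line, Homo sapiens) for inhibition, read by sulforhodamine B assay, with a stated time of 48 h (on this read-out lower numbers stand for stronger inhibition of growth and higher numbers for weaker inhibition of growth), compound 1 `O=S(=O)(Nc1ccc(Cl)c(Cl)c1)c1ccc(-c2cnc(C3CC3)o2)cc1` gives 62100 nM, and compound 2 `O=S(=O)(Nc1ccc(F)cc1F)c1ccc(-c2cnc(C3CC3)o2)cc1` gives 66100 nM. Compound 3 `O=S(=O)(Nc1cc(Cl)ccc1Cl)c1ccc(-c2cnc(C3CC3)o2)cc1` gives > 100000 nM, which is a limit and not a number. Compound 3 thus stands at the limit of > 100000 nM in this assay, at which 1 of the 3 values shown sits.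

Compound 4 `O=S(=O)(Nc1cc(F)cc(Cl)c1)c1ccc(-c2cnc(C3CC3)o2)cc1` carries 3-chloro-5-fluorophenyl in place of 2,5-dichlorophenyl on a sulfonamide nitrogen, a change counted as 3-chloro-5-fluorophenyl in place of 2,5-dichlorophenyl on a sulfonamide nitrogen.

The steps bearing on this are those at the same place. They are a 1.1-fold higher number from compound 1 to compound 2 (0.03 log units; within the scatter), an at least 1.6-fold higher number from compound 1 to compound 3 (0.20 log units; that floor lies within the scatter) and an at least 1.5-fold higher number from compound 2 to compound 3 (0.17 log units; that floor lies within the scatter). None of them is shown beyond the scatter, and the last two are only floors. On these steps, a modest fall in the number is expected, or none beyond the scatter, with a return to the limit also possible. The estimated step is an at least 1.4-fold lower number from compound 3 to compound 4 (0.15 log units; that floor lies within the scatter). In this assay the expected value for compound 4 is 70000 nM, with an estimated range of 40000 nM to 100000 nM.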

Compound 4, concentration for total growth inhibition: 77500 nM
Compound 4: the middle estimate sits 1.1-fold (0.04 log units) below what was measured; low and high end bracket the measured number.
By their numbers in this assay, from the lowest: compounds 1, 2 and 4 (each within the scatter of the next). At a limit, above all of these: compound 3.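

In this assay compound 4, with 3-chloro-5-fluorophenyl on the sulfonamide nitrogen, sits with the two other measured aryl compounds (a 1.2-fold higher number from compound 1 to compound 4 (0.10 log units; within the scatter); a 1.2-fold higher number from compound 2 to compound 4 (0.07 log units; within the scatter)). Compound 3 remains at a limit and not a number, so the new step from it is only a floor (an at least 1.2-fold lower number from compound 3 to compound 4 (0.11 log units; that floor lies within the scatter)). Three halogen patterns on this phenyl therefore show no separation beyond the scatter among compound 1, compound 2 and compound 4, while compound 3 goes unplaced against them: the limit of > 100000 nM in this assay, at which 1 of the 4 values shown sits.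

Whether any group at this place can move the number beyond the scatter stays open, as every aryl group shown carries only halogens. On these data alone, how an amine, a carboxylic acid or a methoxy group on this phenyl would read also stays open.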